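Swapping the Amine Substituent in a Kinase Activator Series

The source may report more compounds than this note shows. Statements on the series, on what has been measured and on what is new or still open speak of the compounds shown alone.

Compound 3 `Cn1ccnc1CN1CCC[C@H](OCc2cc(Cl)cc(Cl)c2)[C@@H]1c1ccccc1` carries a 1-methyl-1H-imidazol-2-yl group on a saturated chain carbon bound to an amine nitrogen in a ring. In an assay on isolated protein for activation of cGMP-dependent protein kinase 1 (Homo sapiens), read by ADP-Glo, with stated times of 120 min and 40 min (on this read-out lower numbers stand for an effect already at smaller amounts and higher numbers for an effect only at larger amounts of compound), compound 3 gives 165000 nM, the highest of the two numbers measured. Compound 2 `O=C(O)c1ccc(CN2CCC[C@H](O[C@H](CO)c3cc(Cl)cc(Cl)c3)[C@@H]2c2ccccc2)cc1` gives 11000 nM in this assay. Compound 1 `Clc1cc(Cl)cc(CO[C@H]2CCCN(Cc3ccccn3)[C@H]2c2ccccc2)c1` reaches only a limit of this assay, > 200000 nM, not a number (the limit of > 200000 nM in this assay, at which 1 of the 3 values shown sits). The step of an at least 1.2-fold lower number from compound 1 to compound 3 (0.08 log units; that floor lies within the scatter) lies within the scatter. Compound 4 `O=C(O)c1ccc(CN2CCC[C@H](OCc3cc(Cl)cc(Cl)c3)[C@@H]2c2ccccc2)cc1` differs from compound 3 by 4-carboxyphenyl in place of 1-methyl-1H-imidazol-2-yl on a saturated chain carbon bound to an amine nitrogen in a ring. Among the compounds with values here, no measured step exchanges exactly these two groups; the nearest point of reference is compound 2, which also carries 4-carboxyphenyl. The expected step is an 11-fold lower number from compound 3 to compound 4 (1.04 log units; beyond the scatter). Compound 4 is thus estimated at 15000 nM, with a range from 5000 nM to 50000 nM.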

Compound 4, half-maximal effective concentration: 76000 nM
The estimate for compound 4 lay 5.1-fold (0.70 log units) below the measured number; the whole stated range lies below it.
By their numbers in this assay, from the lowest: compound 2; then compound 4; then compound 3. At a limit, above all of these: compound 1.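

Within the data shown here, on a saturated chain carbon bound to an amine nitrogen in a ring, 4-carboxyphenyl in place of 1-methyl-1H-imidazol-2-yl gives a 2.2-fold lower number from compound 3 to compound 4 (0.34 log units; beyond the scatter), the first single change here that clearly moves the number. Compound 1 sits at a limit, so the step for 4-carboxyphenyl in place of pyridin-2-yl, an at least 2.6-fold lower number from compound 1 to compound 4 (0.42 log units; beyond the scatter), is only a floor: the limit of > 200000 nM in this assay, at which 1 of the 4 values shown sits. The 4-carboxyphenyl group alone does not reach the number of compound 2, since hydrogen in place of hydroxymethyl gives a 6.9-fold higher number from compound 2 to compound 4 (0.84 log units; beyond the scatter).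

As far as these compounds go, whether an amide or a tetrazole could stand in for the carboxylic acid remains open. So does whether hydroxymethyl would give a similar step alongside 1-methyl-1H-imidazol-2-yl.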